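The compounds below may be only part of what the source reports. "The series", "measured", "known", "first", "only" and "open" are said of these compounds alone.

Measured so far:
- compound 1, `CC(C)=N/N=C1\SCC(=O)N1Cc1ccc(N)cc1`: in a physicochemical assay, with a stated time of 30 min (a lower number here means that less compound is needed, a higher number that more compound is needed for the effect), compound 1 gives 1770000 nM
- compound 2, `C/C(=N/N=C1\SCC(=O)N1Cc1ccc(F)cc1)c1cccs1`: in this assay compound 2 gives 1850000 nM
- compound 3, `C/C(=N/N=C1\SCC(=O)N1Cc1ccccc1[N+](=O)[O-])c1cccs1`: in this assay compound 3 gives 2250000 nM

Among the compounds with values here, all three numbers lie within the usual scatter of one another, so compound 2 cannot be set apart from compound 1 or compound 3; the series so far is flat in this assay despite changes at both ends of the shared core.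

Compound 4, `C/C(=N/N=C1\SCC(=O)N1Cc1ccc(F)cc1)c1ccccn1`, is not yet measured. It differs from compound 2 by pyridin-2-yl in place of thiophen-2-yl on a carbon with a double bond to nitrogen. With the three measured compounds showing no movement beyond the scatter, no step beyond the scatter is expected here in either direction. The expected step is a 1.0-fold higher number from compound 2 to compound 4 (0.01 log units; within the scatter). Compound 4 is estimated at 1900000 nM, with a range from 900000 nM to 4000000 nM.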

Compound 4, half-maximal effective concentration: 1750000 nM
Compound 4: the middle estimate sits 1.1-fold (0.04 log units) above what was measured, within the range that was stated.
By their numbers in this assay, from the lowest: compounds 4, 1, 2 and 3 (each within the scatter of the next).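

With pyridin-2-yl in place of thiophen-2-yl on a carbon with a double bond to nitrogen, the series gains its first comparison at a single position: in this assay the swap gives a 1.1-fold lower number from compound 2 to compound 4 (0.02 log units; within the scatter). A six-membered aromatic ring with one hetero atom thus reads the same here as a five-membered one. No supporting data bear on this result.

From the compounds shown here alone, whether a carboxylic acid, an amine or a longer chain at this position gives a step beyond the scatter remains open. Within the data shown here, the other end of the shared core still has no pair differing in one place.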